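A Carboxyethyl Side Chain Gains a Second Methyl

The compounds below may be only part of what the source reports. "The series", "measured", "known", "first", "only" and "open" are said of these compounds alone.

Compound 1 `C[C@@H](C(=O)O)c1nn(Cc2cn3cc(OCC4CC4)c(Cl)cc3n2)c2ccccc2c1=O` was tested in an ADME assay on microsomes from liver (Mus musculus) for metabolic stability; a higher number here means faster removal of the compound, a lower number slower removal. The result for compound 1 is a limit of the assay, < 55 mL/min/kg. Two other compounds from the same series were measured alongside it. Compound 2 `CCn1nc(CC(=O)Nc2ccc(OC(F)(F)F)c(Cl)c2)c2ccccc2c1=O` gives 81.7 mL/min/kg in this assay. Compound 3 `CCOc1cc2[nH]c(Cc3nn(CC(=O)N4CCOCC4)c(=O)c4ccccc34)nc2cc1Cl` gives 817 mL/min/kg in this assay, the higher of those two numbers. Where compound 1 stands is told only by the limit of < 55 mL/min/kg in this assay, at which 1 of the 3 values shown sits, so it sits at the floor of what the assay reports.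

Compound 4 `CC(C)(C(=O)O)c1nn(Cc2cn3cc(OCC4CC4)c(Cl)cc3n2)c2ccccc2c1=O` has not yet been measured. It differs from compound 1 in a single place: 1-carboxy-1-methylethyl in place of 1-carboxyethyl on an aromatic carbon. Among the measured compounds shown here, no measured pair in this set shows the effect of such a change, so the expectation rests on compound 1 alone. Compound 1 gives only a limit, and the step to compound 4 is expected to stay within the scatter, a step that the limit leaves unreadable from compound 1 to compound 4. Compound 4 is expected to give about 40 mL/min/kg in this assay, between 18 mL/min/kg and 90 mL/min/kg, with a fair chance that the assay again reports only a limit.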

Compound 4, clearance: < 63.4 mL/min/kg
Compound 4: no number, only a limit; the forecaster's own chance of this, stated with the estimate: 60%; the middle value does not contradict the limit.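

Compound 1 and compound 4 both give only limits of the assay in this assay, so no step can be read between them. The compounds shown leave open whether 1-carboxy-1-methylethyl in place of 1-carboxyethyl on an aromatic carbon changes clearance at all.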